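This account rests on a few compounds, and the source may have more. Where it says the series, first, only, none or still open, it means among the compounds named here.

Working notes on the series.

Three compounds share a core and differ only at the carbonyl carbon. Compound 1 `CCN(CC)S(=O)(=O)c1ccc(S(=O)(=O)N2CCC[C@@H](C(=O)N3CCS(=O)(=O)CC3)C2)cc1` carries a 1,1-dioxothiomorpholin-4-yl group there and gives 220 nM in a functional assay on MIA PaCa-2 cells (Homo sapiens) for inhibition, read by MTT assay, with a stated time of 3 days; on this read-out higher numbers stand for weaker inhibition and lower numbers for stronger inhibition. Compound 2 `CCN(CC)S(=O)(=O)c1ccc(S(=O)(=O)N2CCC[C@@H](C(=O)N[C@H]3CC[C@H](OC)CC3)C2)cc1` carries a (4-methoxycyclohexyl)amino group and gives 2290 nM in this assay. Compound 3 `CCN(CC)S(=O)(=O)c1ccc(S(=O)(=O)N2CCC[C@@H](C(=O)N3CCOCC3)C2)cc1` carries a morpholin-4-yl group and gives 160 nM in this assay. Within the data shown here, compound 3 holds the lowest number of the three, but the step of a 1.4-fold lower number from compound 1 to compound 3 (0.14 log units; within the scatter) is within the scatter, so compound 1 and compound 3 are not separable on these numbers; only the step of a 14-fold lower number from compound 2 to compound 3 (1.16 log units; beyond the scatter) is large.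

Compound 4 `CCN(CC)S(=O)(=O)c1ccc(S(=O)(=O)N2CCC[C@@H](C(=O)N3CC[C@@H](OC)C3)C2)cc1` is the next variation at the same carbonyl carbon: 3-methoxypyrrolidin-1-yl in place of morpholin-4-yl on a carbonyl carbon. The two steps that bear on this change are a 1.4-fold lower number from compound 1 to compound 3 (0.14 log units; within the scatter), a swap of one saturated nitrogen ring for another, and a 14-fold lower number from compound 2 to compound 3 (1.16 log units; beyond the scatter), a swap of an open-chain amine for a saturated nitrogen ring. Compound 4 stays on the ring side of that divide, so a small step is expected, if any, and a modest rise cannot be excluded. For compound 4 the expected value is 260 nM, with a range of 100 nM to 700 nM, meaning an expected step of a 1.6-fold higher number from compound 3 to compound 4 (0.21 log units; within the scatter).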

Compound 4, half-maximal inhibitory concentration: 1070 nM
Estimate against measurement, compound 4: 4.1-fold (0.61 log units) below, and the stated range ends below it.
By their numbers in this assay, from the lowest: compounds 3 and 1 (each within the scatter of the next); then compound 4; then compound 2.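

In this assay, the step of a 6.7-fold higher number from compound 3 to compound 4 (0.83 log units; beyond the scatter) shows that this position does not treat all saturated nitrogen rings alike: 3-methoxypyrrolidin-1-yl does not behave like morpholin-4-yl on the carbonyl carbon, although both count one hydrogen-bond acceptor and no donor. The step of a 4.9-fold higher number from compound 1 to compound 4 (0.69 log units; beyond the scatter) sets the new ring apart from 1,1-dioxothiomorpholin-4-yl as well, while a 2.1-fold lower number from compound 2 to compound 4 (0.33 log units; beyond the scatter) leaves it only modestly short of the (4-methoxycyclohexyl)amino compound, so having a ring on the carbonyl carbon does not by itself place a compound with the two lowest numbers, and compound 4 is the case that goes against that reading. Nothing available explains this shift at the carbonyl carbon.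

The change alters ring size, the count of ring hetero atoms, and the methoxy group with its defined stereocentre all at once, so the compounds shown cannot assign the step to any one of these. Plain pyrrolidin-1-yl, the mirror-image 3-methoxypyrrolidin-1-yl and 4-methoxypiperidin-1-yl remain open, and each would separate one of these features from the others.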